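This account rests on a few compounds, and the source may have more. Where it says the series, first, only, none or still open, it means among the compounds named here.

In a functional assay on HepG2 cells (Homo sapiens) for inhibition, read by MTT assay, with a stated time of 72 h; a lower number here means a stronger inhibitor, a higher number a weaker inhibitor:

compound 1 `COc1ccc(NC(=O)C2CCN(C/C=C/c3ccccc3)CC2)cc1`: 88800 nM
compound 2 `COc1cccc(NC(=O)C2CCN(C/C=C/c3ccccc3)CC2)c1`: 78600 nM
compound 3 `O=C(Nc1cccc(F)c1)C1CCN(C/C=C/c2ccccc2)CC1`: 51100 nM

Compound 3 stands within the scatter of both other compounds, so the three values cannot be told apart. Compound 4 `N#Cc1ccc(NC(=O)C2CCN(C/C=C/c3ccccc3)CC2)cc1` carries 4-cyanophenyl in place of 3-fluorophenyl on an amide-type nitrogen. For the measured compounds named here, no measured compound has a nitrile, so the only guide is the swaps already made at this group. All of them stay within the scatter: a 1.1-fold lower number from compound 1 to compound 2 (0.05 log units; within the scatter), a 1.7-fold lower number from compound 1 to compound 3 (0.24 log units; within the scatter) and a 1.5-fold lower number from compound 2 to compound 3 (0.19 log units; within the scatter). No step beyond the scatter is therefore expected in this assay, and the expected step is a 1.2-fold higher number from compound 3 to compound 4 (0.07 log units; within the scatter). Compound 4 is estimated at 60000 nM, with an expected range from 30000 nM to 120000 nM.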

Compound 4, half-maximal inhibitory concentration: 38300 nM
The estimate for compound 4 lay 1.6-fold (0.19 log units) above the measured number; the range from low to high includes it.
By their numbers in this assay, from the lowest: compounds 4, 3, 2 and 1 (each within the scatter of the next, the first and the last beyond it).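

Swapping the group on the amide-type nitrogen now gives a step beyond the scatter, though a modest one, when 4-cyanophenyl replaces 3-methoxyphenyl (a 2.1-fold lower number from compound 2 to compound 4 (0.31 log units; beyond the scatter)) or the methoxy of compound 1 gives way to cyano (a 2.3-fold lower number from compound 1 to compound 4 (0.37 log units; beyond the scatter)). The swap from 3-fluorophenyl stays within the scatter (a 1.3-fold lower number from compound 3 to compound 4 (0.13 log units; within the scatter)), so compound 3 and compound 4 cannot be told apart. Nothing measured here explains the separation from the methoxy compounds. From the compounds shown here alone, how 3-cyanophenyl or 4-aminophenyl would compare with 4-cyanophenyl on this nitrogen remains open.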